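A few compounds are considered here, and "the series" means these few. Any claim that something is new, unique, unknown or untested is made for them only; others in the source may bear on it.

Measured compounds:
compound 1 `C=C(Br)C(=O)Nc1ccc(/C=C2\SC(=O)N(Cc3cccc(F)c3)C2=O)cc1`, 1200 nM
compound 2 `Nc1cccc(/C=C2\SC(=O)N(Cc3cccc(Cl)c3)C2=O)c1`, 211000 nM

Within the data shown here, in a functional assay on L1210 cells (Mus musculus) for cytotoxicity, read by cell counting, with a stated time of 2 days (a lower number here means a stronger inhibitor, a higher number a weaker inhibitor), compound 1 gives 1200 nM, the lowest of the two numbers so far. Compound 2, which carries a different substitution pattern on the shared core, gives in this assay the far higher value 211000 nM, so compound 1 is the stronger inhibitor of the pair. These two differ in more than one place, and no single step can be read between them.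

Compound 3 `C=C(Br)C(=O)Nc1ccc(/C=C2\SC(=O)N(Cc3ccc(C(C)(C)C)cc3)C2=O)cc1` changes compound 1 in one place: 4-(tert-butyl)phenyl in place of 3-fluorophenyl on a saturated chain carbon bound to an amide-type nitrogen in a ring. Among the measured compounds shown here, no measured pair shows this change, so its size cannot be calibrated from data at hand. A modest move toward a higher number is expected, with the step of a 1.7-fold higher number from compound 1 to compound 3 (0.22 log units; within the scatter) lying near the edge of the usual scatter. Compound 3 is therefore estimated at 2000 nM in this assay, with a range from 500 nM to 8000 nM.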

Compound 3, half-maximal inhibitory concentration: 1600 nM
Beside the measured number, compound 3's estimate is 1.3-fold (0.10 log units) above it, within the range that was stated.
By their numbers in this assay, from the lowest: compounds 1 and 3 (each within the scatter of the next); then compound 2.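

In this assay, among these compounds, the exchange of 3-fluorophenyl for 4-(tert-butyl)phenyl gives a 1.3-fold higher number from compound 1 to compound 3 (0.12 log units; within the scatter) and is the first single-place comparison, so the assay does not separate these two groups. At this place, on a saturated chain carbon bound to an amide-type nitrogen in a ring, a group of 10 heavy atoms without fluorine stands in for one of 7 with fluorine, and the two compounds read alike; this holds for this one pair only. No supporting measurement bears on this result.

From the compounds shown here alone, what a carboxylic acid or a morpholine in place of 4-(tert-butyl)phenyl would give in this assay stays open, as does a longer chain in place of the saturated chain carbon. Also open, going by these compounds, is whether the same exchange reads alike on the core of compound 2.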